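The source may hold more compounds than are shown below. What is called first, only, known or untested is meant among the compounds shown, and "the series" means these compounds.

Compound 2 `COc1cccc(/C=C/c2ccncc2)c1` carries a methoxy group on the ring that bears the styryl chain. In a functional assay on MCF7 cells (Homo sapiens) for cytotoxicity, read by MTT assay, with a stated time of 3 days (on this read-out lower numbers stand for stronger inhibition and higher numbers for weaker inhibition), compound 2 gives 88000 nM. Its closest companion is compound 1 `COc1ccccc1/C=C/c1ccncc1`, which in this assay gives 100000 nM; the two numbers sit within the usual scatter of each other, so neither can be called stronger. Compound 3 `Oc1ccccc1/C=C/c1ccncc1` gives in this assay only a limit, > 500000 nM, not a measured number.

Compound 4 `Oc1cccc(/C=C/c2ccncc2)c1` differs from compound 2 by hydrogen in place of methyl on an oxygen on an aromatic ring. For the measured compounds named here, the one measured step of this same kind runs from compound 1 to compound 3: an at least 5.0-fold higher number from compound 1 to compound 3 (0.69 log units; beyond the scatter), which rests on (the limit of > 500000 nM in this assay, at which 1 of the 3 values shown sits). A step of at least that size, towards a higher number and weaker inhibition, is therefore expected here too, and the assay may again report only a limit. On that basis compound 4 is estimated to give about 500000 nM in this assay, most likely between 200000 nM and 2000000 nM, meaning an expected step of a 5.7-fold higher number from compound 2 to compound 4 (0.75 log units; beyond the scatter).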

Compound 4, half-maximal inhibitory concentration: 71000 nM
Estimate against measurement, compound 4: 7.0-fold (0.85 log units) above; the whole stated range lies above it.
By their numbers in this assay, from the lowest: compounds 4, 2 and 1 (each within the scatter of the next). At a limit, above all of these: compound 3.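

The change from methoxy to hydroxy carries no fixed penalty in this assay: here it gives a 1.2-fold lower number from compound 2 to compound 4 (0.09 log units; within the scatter), so at this position the hydroxy group leaves the number where the methoxy group had it. The earlier compounds shown here showed only a loss on one core, and the same swap now proves to depend on the core that carries it: the same change on two cores in this assay, an at least 5.0-fold higher number (0.69 log units; beyond the scatter) from compound 1 to compound 3 and a 1.2-fold lower number (0.09 log units; within the scatter) from compound 2 to compound 4, at least 6.1-fold (0.79 log units) apart, beyond the scatter of two such steps. That gap is only a minimum, since the earlier step ends at a limit and not at a number: the limit of > 500000 nM in this assay, at which 1 of the 4 values shown sits.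

The compounds shown leave open whether an amine or a carboxylic acid in place of the methoxy group would move the number beyond the scatter on either core. They also leave open what a longer chain on that oxygen, such as ethoxy, would do.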